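Adding one methyl to the ring of compound 1

This account rests on a few compounds, and the source may have more. Where it says the series, first, only, none or still open, it means among the compounds named here.

- Compound 1 `CNc1nc(NC2(C#N)CCCCC2)nc(-n2cncn2)n1`: 11 ug/mL
- Compound 2 `CCC(C)(C#N)Nc1nc(NC)nc(-n2cncn2)n1`: 50 ug/mL

In a physicochemical assay for solubility, at pH 7.4 (a higher number here means a more soluble compound, a lower number a less soluble compound), compound 1 has the lower of the two numbers at 11 ug/mL, and compound 2 reaches 50 ug/mL, a gap beyond the usual scatter. Compound 3 `CNc1nc(NC2(C#N)CCCCC2C)nc(-n2cncn2)n1` differs from compound 1 in one place: methyl in place of hydrogen on a saturated ring carbon. Among the measured compounds shown here, no measured pair shows this change, so the expectation in this assay is rough: a small downward step, probably none beyond the scatter. The expected step is a 1.2-fold lower number from compound 1 to compound 3 (0.09 log units; within the scatter). Compound 3 is estimated at 9 ug/mL, within a range from 3.5 ug/mL to 22 ug/mL.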

Compound 3, solubility: 25 ug/mL
The estimate for compound 3 lay 2.8-fold (0.44 log units) below the measured number; measured number above the stated range.
By their numbers in this assay, from the lowest: compound 1; then compounds 3 and 2 (each within the scatter of the next).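

In this assay, methyl in place of hydrogen on a saturated ring carbon, next to the ring atom that bears a cyano group, gives a 2.3-fold higher number from compound 1 to compound 3 (0.36 log units; beyond the scatter). Among the compounds shown here, this position therefore takes the added carbon with a rise in the number, something the earlier compounds could not show, since neither differed from the other in one place only. Nothing shown here bears on why the number rises. On these data alone, whether an ethyl chain, a hydroxyl or an amine at this same carbon would shift the number in the same direction remains open.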